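Second chloro on the core of a benzylpurine

The source may hold more compounds than are shown below. What is called first, only, known or untested is meant among the compounds shown, and "the series" means these compounds.

Measured compounds:
Compound 1 `ClCc1cccc(Cn2cnc3c(Cl)ncnc32)c1`: 13500 nM
Compound 2 `ClCc1ccc(Cn2cnc3nc(Cl)nc(Cl)c32)cc1`: 670 nM

In a functional assay on KM12 cells (Homo sapiens) for cytotoxicity, read by sulforhodamine B assay, with a stated time of 48 h (a lower number here means a stronger inhibitor of growth, a higher number a weaker inhibitor of growth), compound 1 gives 13500 nM, the highest number of the two, while compound 2 gives 670 nM, a difference well beyond the scatter. Compound 2, however, differs from compound 1 in two places, so its value alone does not isolate either change.

Going by the values given here, compound 3 `ClCc1cccc(Cn2cnc3c(Cl)nc(Cl)nc32)c1` takes only one of those changes: chloro in place of hydrogen on an aromatic carbon, on the aromatic carbon between two ring nitrogen atoms. Among the compounds with values here, no measured pair isolates this change, so the expectation leans on compound 2 alone. Compound 3 is expected to move in the direction of compound 2, with a step from compound 1 of a 9.0-fold lower number from compound 1 to compound 3 (0.95 log units; beyond the scatter) in this assay, beyond the scatter. Compound 3 is therefore estimated to give 1500 nM in this assay, within a range from 400 nM to 6000 nM.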

Compound 3, concentration for total growth inhibition: 3800 nM
Beside the measured number, compound 3's estimate is 2.5-fold (0.40 log units) below it; measured number inside the range.
By their numbers in this assay, from the lowest: compound 2; then compound 3; then compound 1.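

Going by these compounds alone, with chloro in place of hydrogen on the aromatic carbon between two ring nitrogen atoms as the only change, this assay records a 3.6-fold lower number from compound 1 to compound 3 (0.55 log units; beyond the scatter) as a modest step, which shows that this position responds to the change on its own. That step covers only part of the distance to compound 2, since compound 3 gives 3800 nM while compound 2 gives 670 nM in the same assay, leaving the rest of the gap with the one other place in which they differ. Nothing at hand explains the step.

Going by these compounds, the result rests on a single pair, so it remains open whether an amine or a methoxy group on this same carbon would move the number as chloro does. On these data alone, it is also open whether chloro would give a step of similar size with the other substituent arrangement seen in compound 2.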